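Shortening the Hydroxyalkoxy Chain: What to Expect for Compound 4

The source may report more compounds than this note shows. Statements on the series, on what has been measured and on what is new or still open speak of the compounds shown alone.

Compound 1 `COc1cccc(/C=C/C(=O)NCCn2c(C)cc3ccccc32)c1`: 29.2 nM
Compound 2 `Cc1cc2ccccc2n1CCNC(=O)/C=C/c1ccc(OCCCO)cc1`: 11.8 nM
Compound 3 `COc1ccc(/C=C/C(=O)NCCn2c(C)cc3ccccc32)cc1`: 16.5 nM

All three were tested in an assay on C6 cells for antagonist activity at prostaglandin E2 receptor EP2 subtype (Homo sapiens), read by TR-FRET, with stated times of 10 min and 40 min, tested at 1 uM; on this read-out higher numbers stand for weaker inhibition and lower numbers for stronger inhibition. Compound 3 stands second highest of the three numbers, with compound 2 nearest and compound 1 furthest; both steps fall within the scatter: a 1.8-fold lower number from compound 1 to compound 3 (0.25 log units; within the scatter), and a 1.4-fold higher number from compound 2 to compound 3 (0.15 log units; within the scatter). Compound 4 `Cc1cc2ccccc2n1CCNC(=O)/C=C/c1ccc(OCCO)cc1` differs from compound 3 by hydroxymethyl in place of hydrogen on a saturated chain carbon bound to an oxygen on an aromatic ring. Among the measured compounds shown here, the one measured step that bears on this change is a 1.4-fold higher number from compound 2 to compound 3 (0.15 log units; within the scatter), which runs the same kind of change in the opposite direction, with a longer chain. Since that step stayed within the scatter, the change to compound 4 is expected to give no step beyond the scatter either: a 1.3-fold lower number from compound 3 to compound 4 (0.10 log units; within the scatter). Compound 4 is therefore estimated at 13 nM, in the range 6 nM to 28 nM.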

Compound 4, antagonist equilibrium constant: 13.6 nM
Compound 4: middle estimate off by 1.0-fold (0.02 log units), on the low side; the measured number falls inside the stated range.
By their numbers in this assay, from the lowest: compounds 2, 4, 3 and 1 (each within the scatter of the next, the first and the last beyond it).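

Hydroxymethyl in place of hydrogen on the saturated chain carbon gives a 1.2-fold lower number from compound 3 to compound 4 (0.08 log units; within the scatter), and hydroxy in place of hydroxymethyl gives a 1.2-fold higher number from compound 2 to compound 4 (0.06 log units; within the scatter). Among the compounds shown here, the 2-hydroxyethoxy group of compound 4 thus joins the methoxy of compound 3 and the longer hydroxyalkoxy chain of compound 2, with no step among the three beyond the scatter. No measurement at hand offers a reason for this result. On these data alone, what stays open is whether an amine or a carboxylic acid in place of the hydroxy, or a still longer chain, would give a step beyond the scatter.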